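The source may hold more compounds than are shown below. What is called first, only, known or untested is meant among the compounds shown, and "the series" means these compounds.

Compound 2, `N#Cc1cc(C(=O)Nc2nc(-c3cccc(C(F)(F)F)c3F)cs2)cnc1N1CCC(C(=O)O)CC1`, stands only at a limit in a physicochemical assay for solubility; a higher number here means a more soluble compound, a lower number a less soluble compound: compound 2 gives < 10 ug/mL, a limit of the assay rather than a number. Among the measured compounds shown here, the one measured neighbour, compound 1, `O=C(Nc1nc(-c2cccc(C(F)(F)F)c2F)cs1)c1cnc(N2CCC(C(=O)O)CC2)c(Br)c1`, gives < 10 ug/mL, likewise a limit. The step that the two limits leave unreadable from compound 1 to compound 2 therefore cannot be sized, and the limit of < 10 ug/mL in this assay, at which 2 of the 2 values shown sit, is all the evidence there is. Compound 3, `Cc1cc(C(=O)Nc2nc(-c3cccc(C(F)(F)F)c3F)cs2)cnc1N1CCC(C(=O)O)CC1`, differs from compound 2 by methyl in place of cyano on an aromatic carbon. No readable step bears on this change, so the size expected in this assay rests on the two limits alone. Compound 3 is estimated at 8 ug/mL, between 2 ug/mL and 30 ug/mL, a step that the limit leaves unreadable from compound 2 to compound 3 from compound 2, and the measurement will decide.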

Compound 3, solubility: < 10 ug/mL
Compound 3: only a limit was reported (the forecaster's own chance of this, stated with the estimate: 60%); the middle value does not contradict the limit.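

No step can be read between compound 3 and either compound 1 or compound 2 in this assay, as all three stop at one limit: the limit of < 10 ug/mL in this assay, at which 3 of the 3 values shown sit.

The compounds shown leave open how bromo, cyano and methyl on that aromatic carbon rank in solubility.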